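Trading an Acid Chain for a Cyclic Amide

A few compounds are considered here, and "the series" means these few. Any claim that something is new, unique, unknown or untested is made for them only; others in the source may bear on it.

Compound 1 `Cc1nc(-c2ccc(C(F)(F)F)cc2)sc1CNc1ccc(CCCC(=O)O)cc1` was tested in a functional assay on CHO cells for agonist activity at Free fatty acid receptor 1 (Homo sapiens); a higher number here means that more compound is needed for the effect, a lower number that less compound is needed. For compound 1 the result is recorded only as a limit, < 10000 nM, not as a measured number. A second compound, compound 2 `O=C(O)[C@@H]1C[C@H]1c1ccc(NCc2cccc(Oc3ccccc3)c2)cc1`, shares part of its skeleton with compound 1 but carries a different tail and a different acid; in this assay compound 2 gives 562 nM. For the measured compounds named here, no two compounds here differ in a single place, so no measured step exists to lean on. Compound 3 `Cc1nc(-c2ccc(C(F)(F)F)cc2)sc1CNc1ccc([C@H]2C[C@@H]2C(=O)NC2CCNC2)cc1` is the compound whose value is awaited. It differs from compound 1 in one place: 2-((pyrrolidin-3-yl)carbamoyl)cyclopropyl in place of 3-carboxypropyl on an aromatic carbon. Going by the values given here, the only information on compound 1 is the limit of < 10000 nM in this assay, at which 1 of the 2 values shown sits, so the size of the step cannot be set against a firm starting number; a step toward needing more compound, beyond the usual scatter, seems likelier than one toward needing less. Compound 3 is estimated at 5000 nM, with a range from 1500 nM to 20000 nM, meaning an expected step that the limit leaves unreadable from compound 1 to compound 3.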

Compound 3, half-maximal effective concentration: 204 nM
The estimate for compound 3 lay 25-fold (1.39 log units) above the measured number; the measured number lies below the stated range.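

Compound 1 is recorded only as a limit, so no size can be given to its step to compound 3: the limit of < 10000 nM in this assay, at which 1 of the 3 values shown sits. The compounds shown leave open which part of the 2-((pyrrolidin-3-yl)carbamoyl)cyclopropyl group, the three-membered ring or the five-membered ring, goes with the value of compound 3.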